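The compounds below may be only part of what the source reports. "The series", "measured", "known", "first", "only" and "open" are said of these compounds alone.

Measured so far:
Compound 1 `Cc1noc(-c2nc(C)c3c(c2N)C(=O)N(Cc2ccc(Cl)cc2)C3=O)n1`: < 5000 nM
Compound 2 `Cc1noc(-c2nc(C)c3c(c2N)C(=O)N(Cc2ccc(S(C)(=O)=O)cc2)C3=O)n1`: < 5000 nM

In a physicochemical assay for solubility, using the shake flask method, in simulated intestinal fluid, measured as kinetic solubility, with a stated time of 2 h, at 25 degrees C, at pH 6.5 (a higher number here means a more soluble compound, a lower number a less soluble compound), compound 2 gives < 5000 nM, which is a limit of the assay and not a number. Compound 1 gives < 5000 nM, also a limit. The evidence so far is therefore (the limit of < 5000 nM in this assay, at which 2 of the 2 values shown sit). Compound 3 `Cc1noc(-c2nc(C)c3c(c2N)C(=O)N(Cc2ccc(N4CCCC4=O)cc2)C3=O)n1` keeps the shared core and carries 2-oxopyrrolidin-1-yl in place of methylsulfonyl on an aromatic carbon, (2-oxopyrrolidin-1-yl in place of methylsulfonyl on an aromatic carbon). Within the data shown here, the one measured step at this place is a step that the two limits leave unreadable from compound 1 to compound 2, with methylsulfonyl in place of chloro, so it offers no size to carry over. No step beyond the usual scatter is expected in this assay, and no direction can be named. This expectation rests on compound 2 and its limit of < 5000 nM. The estimated step is a step that the limit leaves unreadable from compound 2 to compound 3. For compound 3 the expected value is 2500 nM, with an estimated range from 600 nM to 5000 nM.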

Compound 3, solubility: < 5000 nM
Compound 3 ended at the assay's limit; the forecaster's own chance of this, stated with the estimate: 70%; the middle value does not contradict the limit.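

Among these compounds, no step among compound 1, compound 2 and compound 3 can be read in this assay, since all three values are limits of the assay and not numbers: the limit of < 5000 nM in this assay, at which 3 of the 3 values shown sit. The compounds shown leave open how far apart their true values lie, and whether exchanging chloro, methylsulfonyl and 2-oxopyrrolidin-1-yl makes any difference.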